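Headgroup exchange on the amide nitrogen of compound 1

The source may report more compounds than this note shows. Statements on the series, on what has been measured and on what is new or still open speak of the compounds shown alone.

Measured compounds:
compound 1 `O=C(NO)c1ccc(N(Cc2ccc(C3CCCCC3)cn2)C(=O)[C@H]2CCN2S(=O)(=O)c2c(F)c(F)c(F)c(F)c2F)c(F)c1`: 5800 nM
compound 2 `O=C(NO)c1ccc(N(Cc2ccc(C3CCCC3)cn2)C(=O)[C@H]2CCN2S(=O)(=O)c2c(F)c(F)c(F)c(F)c2F)c(F)c1`: "not determined" (no result reported)
compound 3 `O=C(NO)c1ccc(N(Cc2cnc(C3CCCCC3)cn2)C(=O)[C@H]2CCN2S(=O)(=O)c2c(F)c(F)c(F)c(F)c2F)c(F)c1`: "not determined" (no result reported)

In a functional assay on MDA-MB-231 cells (Homo sapiens) for antiproliferative activity, with a stated time of 72 h (a lower number here means that less compound is needed, a higher number that more compound is needed for the effect), compound 1 gives 5800 nM. Among the measured compounds shown here, this is the only number in the set; compound 2 shows "not determined" (no result reported) and compound 3 shows "not determined" (no result reported), so compound 1 cannot be placed against anything measured. Compound 4 `O=C1NCc2cc(N(Cc3ccc(C4CCCCC4)cn3)C(=O)[C@H]3CCN3S(=O)(=O)c3c(F)c(F)c(F)c(F)c3F)ccc21` differs from compound 1 by a group of 10 heavy atoms (8 carbon, 1 nitrogen, 1 oxygen; one five-membered non-aromatic ring with 1 hetero atom, one six-membered aromatic ring of carbon only) in place of a group of 11 heavy atoms (7 carbon, 1 nitrogen, 2 oxygen, 1 fluorine; one six-membered aromatic ring of carbon only), on an amide-type nitrogen. For the measured compounds named here, no step between two measured compounds is available, so the size of such a change cannot be calibrated from this series. The expectation for compound 4 is that more compound will be needed, with a step of a 3.1-fold higher number from compound 1 to compound 4 (0.49 log units; beyond the scatter) expected beyond the scatter. The estimate for compound 4 in this assay is 18000 nM, within 4000 nM to 80000 nM, with a fair chance that only a limit is reported.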

Compound 4, half-maximal effective concentration: 2000 nM
The estimate for compound 4 lay 9.0-fold (0.95 log units) above the measured number, outside the stated range (below it).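

In this assay, the position on the amide-type nitrogen tolerates loss of the 2-fluoro-4-(hydroxycarbamoyl)phenyl group: the exchange gives a 2.9-fold lower number from compound 1 to compound 4 (0.46 log units; beyond the scatter). Activity in this series therefore does not depend on the hydroxycarbamoyl group, at least at this level of potency. Nothing available bears on the reason for the step. From the compounds shown here alone, the exchange removes the fluorine and the hydroxycarbamoyl group and adds the five-membered non-aromatic ring all at once, so the contribution of each remains open. Going by these compounds, whether a carboxylic acid or a primary amide would serve at this position also remains open.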